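This account rests on a few compounds, and the source may have more. Where it says the series, first, only, none or still open, it means among the compounds named here.

Measured in a functional assay on HL-60 cells (Homo sapiens) for antiproliferative activity, with a stated time of 72 h; on this read-out lower numbers stand for stronger inhibition and higher numbers for weaker inhibition:
- compound 1 `Nc1ncnn2c([C@@H]3O[C@H](CO)[C@@H](O)[C@H]3O)cc(C#CC3CC3)c12`: 40 nM
- compound 2 `Cc1ccccc1-c1cc([C@@H]2O[C@H](CO)[C@@H](O)[C@H]2O)n2ncnc(N)c12`: 48400 nM

Compound 2 has the higher of the two numbers, so it is the weaker inhibitor of this pair. Compound 3 `Nc1ncnn2c([C@@H]3O[C@H](CO)[C@@H](O)[C@H]3O)cc(-c3ccsc3)c12` keeps the shared core but has thiophen-3-yl in place of 2-methylphenyl on an aromatic carbon. Going by the values given here, only one measured step bears on this change, a 1200-fold higher number from compound 1 to compound 2 (3.08 log units; beyond the scatter). That step is large and beyond the scatter, so swapping the group at this place can shift the number strongly. Among the compounds with values here, no thiophen-3-yl compound has been measured, which makes this a thin guide. Since compound 1 reaches 40 nM with a different group at this place, a large step towards a lower number is expected, though not all the way to compound 1. The expected change is a 120-fold lower number from compound 2 to compound 3 (2.08 log units; beyond the scatter). For compound 3, the estimated value is 400 nM, with an expected range of 40 nM to 5000 nM.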

Compound 3, half-maximal inhibitory concentration: 37300 nM
Estimate against measurement, compound 3: 93-fold (1.97 log units) below, outside the stated range (above it).
By their numbers in this assay, from the lowest: compound 1; then compounds 3 and 2 (each within the scatter of the next).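

In this assay thiophen-3-yl in place of 2-methylphenyl gives a 1.3-fold lower number from compound 2 to compound 3 (0.11 log units; within the scatter) and so does not separate these two aromatic rings, although they differ in ring size and one contains sulfur. Compared with 2-cyclopropylethynyl, the same group gives a 930-fold higher number from compound 1 to compound 3 (2.97 log units; beyond the scatter) at this place on the shared core. The large gap first seen with 2-methylphenyl is therefore not unique to that group, as it also appears with a second aromatic ring. No measurement here explains this difference between the groups.

The compounds shown leave open whether the low number of compound 1 depends on the triple bond or on the cyclopropyl ring at its end. A plain ethynyl group, a propynyl chain or a saturated 2-cyclopropylethyl chain at this place would help tell these apart.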